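A Methyl Added to the Sulfonamide Side Chain

The source may hold more compounds than are shown below. What is called first, only, known or untested is meant among the compounds shown, and "the series" means these compounds.

In a functional assay on A549 cells (Homo sapiens) for antiproliferative activity, read by MTT assay, with a stated time of 48 h (on this read-out lower numbers stand for stronger inhibition and higher numbers for weaker inhibition), compound 1 (`O=C(/C=C/c1ccc([N+](=O)[O-])cc1)N1Cc2ccccc2[C@@H](OCc2ccccc2)[C@@H]1CO`) gives 5620 nM and compound 2 (`Cc1ccc(S(=O)(=O)NCC(=O)N2Cc3ccccc3[C@@H](OCc3ccccc3)[C@@H]2CO)cc1`) gives 6030 nM. The two share a core but carry different side chains on its amide nitrogen. Their numbers lie within the usual scatter of each other, so compound 2 stands level with compound 1 and neither can be ranked above the other.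

Compound 3 (`Cc1ccc(S(=O)(=O)N[C@@H](C)C(=O)N2Cc3ccccc3[C@@H](OCc3ccccc3)[C@@H]2CO)cc1`) departs from compound 2 by one small edit, methyl in place of hydrogen on a saturated chain carbon bound to a carbonyl carbon and a sulfonamide nitrogen. Going by the values given here, no measured pair in this set isolates such a change, so any forecast is tentative. It rests on compound 1 at 5620 nM and compound 2 at 6030 nM, whose far larger difference in side chain leaves no separation beyond the scatter. No shift beyond the scatter is therefore expected in this assay, and no direction is favoured. The expected step is a 1.1-fold lower number from compound 2 to compound 3 (0.04 log units; within the scatter), which is estimated to stay within the scatter. Compound 3 is expected at about 5500 nM, with an estimated range of 2500 nM to 12000 nM.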

Compound 3, half-maximal inhibitory concentration: 7370 nM
Compound 3: middle estimate off by 1.3-fold (0.13 log units), on the low side, and the stated range covers the measured number.
By their numbers in this assay, from the lowest: compounds 1, 2 and 3 (each within the scatter of the next).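

Going by these compounds alone, the methyl in place of hydrogen on a saturated chain carbon bound to a carbonyl carbon and a sulfonamide nitrogen offers the first comparison here in which two compounds differ in one place, and in this assay it gives a 1.2-fold higher number from compound 2 to compound 3 (0.09 log units; within the scatter). This shows that this carbon accepts a single added methyl without a separation from the hydrogen compound that this read-out can resolve, which the comparison of compound 1 with compound 2, with their wholly different side chains, could not show. No supporting measurement is available to account for this result.

The compounds shown leave open whether a larger group on this carbon, such as isopropyl or benzyl, or an amine or a carboxylic acid carried on a longer chain, would separate from compound 2 beyond the scatter. They also leave open how the methyl in the opposite spatial arrangement at this carbon would read in this assay, since compound 3 shows only one arrangement.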